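The compounds below may be only part of what the source reports. "The series", "measured", "known", "first", "only" and "open" are said of these compounds alone.

Compound 1 `CN1O[C@@H](n2cc(-c3ccccc3)nn2)C[C@@H]1CO` and compound 2 `CN1O[C@H](n2cc(-c3ccccc3)nn2)C[C@@H]1CO` share one core and differ only in how one stereocentre is drawn. In a functional assay on 8305C cells (Homo sapiens) for cytotoxicity, read by MTT assay, with a stated time of 24 h (a higher number here means a weaker inhibitor, a lower number a stronger inhibitor), compound 1 gives 7140 nM, and compound 2 gives 8760 nM. The step of a 1.2-fold higher number from compound 1 to compound 2 (0.09 log units; within the scatter) shows that this change in configuration leaves the read-out essentially where it was, which rests on (the fact that compounds 1 and 2 differ only in the configuration as drawn). Among the two numbers so far, compound 2 has the higher one, yet it sits within the scatter of compound 1, so the two cannot be ranked.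

Compound 3 `CCCc1cn([C@@H]2C[C@H](CO)N(C)O2)nn1` arises from compound 2 by a different kind of change: propyl in place of phenyl on an aromatic carbon. For the measured compounds named here, no measured step concerns a swap of this sort; the only step in hand, the stereochemical one, was within the scatter and says nothing about replacing an aromatic ring with a short chain. The expectation for compound 3 therefore rests on little more than the neighbourhood of compound 2, and a modest move toward a higher number, a 1.6-fold higher number from compound 2 to compound 3 (0.20 log units; within the scatter), is estimated with wide uncertainty. On that basis compound 3 is expected to give about 14000 nM in this assay, somewhere between 4500 nM and 45000 nM.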

Compound 3, half-maximal inhibitory concentration: 6870 nM
Estimate against measurement, compound 3: 2.0-fold (0.31 log units) above; measured number inside the range.
By their numbers in this assay, from the lowest: compounds 3, 1 and 2 (each within the scatter of the next).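

In this assay the swap of phenyl for propyl on this aromatic carbon of the five-membered ring gives a 1.3-fold lower number from compound 2 to compound 3 (0.11 log units; within the scatter) and so leaves the read-out where it was, even though the group that enters has no ring at all. The earlier pair showed only that redrawing one stereocentre made no measurable difference, whereas this pair shows that an aromatic ring at this position is not required to hold the number at this level, at least for propyl with the configuration of compound 2. Nothing measured here accounts for why the two groups cannot be told apart in this cytotoxicity read-out.

The compounds shown leave open whether a longer chain, an amine or a carboxylic acid on this aromatic carbon would move the number beyond the scatter, and whether propyl would behave the same way with the stereocentre drawn as in compound 1. For the compounds shown here, every step so far lies within the scatter, and which change at this position could shift the read-out at all remains unknown.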